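The source may hold more compounds than are shown below. What is called first, only, known or untested is meant among the compounds shown, and "the series" means these compounds.

Of the compounds shown here, three measured so far share a sulfonyl-linked aryl group and differ either in that aryl group or in the core that carries it. Compound 1 `Cc1ccc2ncc(S(=O)(=O)c3ccc(Cl)c(Cl)c3)c(N3CCC(C)CC3)c2c1` bears a 3,4-dichlorophenyl on the sulfonyl sulfur, and in an assay on isolated protein for displacement of a labelled ligand from metabotropic glutamate receptor 5 (Homo sapiens), with a stated time of 60 min, tested at 1 uM (on this read-out lower numbers stand for less inhibition and higher numbers for more inhibition at the one concentration tested (going by the name of the read-out)), compound 1 gives 82%. Compound 2 `Cc1ccc2ncc(S(=O)(=O)c3ccc(C)c(C)c3)c(N3CCC(C)CC3)c2c1` bears a 3,4-dimethylphenyl at that position, and in this assay compound 2 gives 90%. Compound 3 `Cc1ccc(S(=O)(=O)c2cnc3cc(Cl)ccc3c2N2CCC(C)CC2)cc1C` keeps the 3,4-dimethylphenyl but sits on a different core, and in this assay compound 3 gives 86%. The difference between the core of compound 3 and the core of compound 2 is not broken down here; their two values lie within the usual scatter of each other, as do the values of compound 3 and compound 1.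

One change is followed directly in the measured set, (3,4-dichlorophenyl in place of 3,4-dimethylphenyl on a sulfonyl sulfur), and it gave a number 8 percentage points lower from compound 2 to compound 1 (within the scatter).

Compound 4 `CC1CCN(c2c(S(=O)(=O)c3ccc(Cl)c(Cl)c3)cnc3cc(Cl)ccc23)CC1` has not yet been measured. It stands to compound 3 as compound 1 stands to compound 2: 3,4-dichlorophenyl in place of 3,4-dimethylphenyl on a sulfonyl sulfur. The surroundings of the change are described in the same words in both cases, so the step is the same change carried out on the core of compound 3.

Because the measured step is a number 8 percentage points lower from compound 2 to compound 1 (within the scatter) and compound 3 gives 86%, the change to compound 4 is expected to amount to a number 7 percentage points lower from compound 3 to compound 4 (within the scatter). In this assay compound 4 is therefore estimated at 79%, with a likely range from 66% to 90%.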

Compound 4, a percentage reported as inhibition, at one concentration (the size of the read-out at that concentration, not a potency): 89%
Compound 4: the middle estimate sits 10 percentage points below what was measured; the measured number falls inside the stated range.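

On the core of compound 3, placing 3,4-dichlorophenyl in place of 3,4-dimethylphenyl on the sulfonyl sulfur gave, in this assay, a number 3 percentage points higher from compound 3 to compound 4 (within the scatter). Set beside the same change on the other core, the two steps do not differ by more than repeated measurements of this kind would allow: the same change on two cores in this assay, a number 8 percentage points lower (within the scatter) from compound 2 to compound 1 and a number 3 percentage points higher (within the scatter) from compound 3 to compound 4, 11 percentage points apart, within the scatter of two such steps This shows that, on these two cores, the exchange of the two aryl groups produced no step that stands clear of the scatter, so the two cores offer no sign that the change behaves differently from one to the other; it does not show that the change has the same effect on both, or any effect at all, and with one concentration and only two pairs it says nothing about potency or about other cores.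

The compounds shown leave open what happens when the aryl group on the sulfonyl sulfur carries a methoxy group, an amine or a carboxylic acid, or gives way to a longer alkyl chain. They also leave open how the same exchange would read on a core bearing a nitrile.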